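The source may hold more compounds than are shown below. What is called first, only, known or untested is meant among the compounds shown, and "the series" means these compounds.

Compound 1 `O=C(NC1CCN(c2ncnc3[nH]ncc23)CC1)c1ccc(F)cc1` gives 4540 nM in an assay on isolated protein for inhibition of serine/threonine-protein kinase PAK 1 (Homo sapiens), read by ADP-Glo, with a stated time of 40 min; on this read-out lower numbers stand for stronger inhibition and higher numbers for weaker inhibition. Within the data shown here, compound 2 `O=C(NC1CCN(c2ncnc3[nH]ncc23)CC1)c1ccc(Br)cc1` carries bromo where compound 1 has fluoro; in this assay compound 2 gives 16400 nM, which is the higher of the two numbers measured so far, and the only measured step, a 3.6-fold higher number from compound 1 to compound 2 (0.56 log units; beyond the scatter), separates it from its nearest neighbour. Compound 3 `O=C(NC1CCN(c2ncnc3[nH]ncc23)CC1)c1ccc(C(F)(F)F)cc1` differs from compound 2 by one change: trifluoromethyl in place of bromo on an aromatic carbon, on an aromatic carbon of a six-membered aromatic ring of carbon only, para to a large group. Among the measured compounds shown here, the one step on record, from a small to a large halogen, was modest and upward, and no measured pair shows what trifluoromethyl does here; on this thin basis the step from compound 2 to compound 3 is expected to be small, a 1.1-fold lower number from compound 2 to compound 3 (0.04 log units; within the scatter), most likely within the scatter. Compound 3 is therefore estimated at 15000 nM in this assay, with a range from 5000 nM to 45000 nM.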

Compound 3, half-maximal inhibitory concentration: 5740 nM
Compound 3: the middle estimate sits 2.6-fold (0.42 log units) above what was measured; measured number inside the range.
By their numbers in this assay, from the lowest: compounds 1 and 3 (each within the scatter of the next); then compound 2.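

At this position, on an aromatic carbon para to a large group, trifluoromethyl in place of bromo gives a 2.9-fold lower number from compound 2 to compound 3 (0.46 log units; beyond the scatter), so a group with more heavy atoms than bromo does not push the number further up. Trifluoromethyl in place of fluoro gives a 1.3-fold higher number from compound 1 to compound 3 (0.10 log units; within the scatter), so these two groups cannot be told apart here, and among the three only bromo stands out, with the higher number. No measurement at hand explains why bromo differs from the other two groups.

On these data alone, it remains open whether an amine, a methoxy group or a carboxylic acid at this position would give a number clearly lower than those of compound 1 and compound 3. The effect of plain hydrogen there, with no group at all, is also still unknown.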